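The source may hold more compounds than are shown below. What is called first, only, known or untested is meant among the compounds shown, and "the series" means these compounds.

Compound 3 `Cc1ccc(CN2CCC(C(=O)Nc3ccc(CNc4nc(N(C)C)nc5cc(C)ccc45)cc3)CC2)cc1` is one of three related compounds tested in a functional assay on SV5A8 cells (Homo sapiens) for cytotoxicity; a lower number here means a stronger inhibitor, a higher number a weaker inhibitor. In this assay compound 3 gives > 4150 nM, which is a limit of the assay rather than a number. Compound 1 `Cc1ccc2c(NCc3ccc(NC(=O)C4CCN(Cc5ccc(F)cc5)CC4)cc3)nc(N(C)C)nc2c1` likewise gives only a limit, > 4820 nM. Compound 2 `Cc1ccc2c(NCc3ccc(NC(=O)C4CCN(Cc5ccccc5)CC4)cc3)nc(N3CCC3)nc2c1` also gives only a limit, > 8500 nM. The one step that joins two of these compounds, a step that the two limits leave unreadable from compound 1 to compound 3, cannot be sized, since both of its ends are limits. Compound 4 `Cc1ccc2c(NCc3ccc(NC(=O)C4CCN(Cc5ncc[nH]5)CC4)cc3)nc(N(C)C)nc2c1` differs from compound 3 in one place: 1H-imidazol-2-yl in place of 4-methylphenyl on a saturated chain carbon bound to an amine nitrogen in a ring. Among the compounds with values here, no measured step bears on this change, and the three limits give no anchor for it. Compound 4 is therefore expected to give only a limit as well, with an estimated 10000 nM in this assay, between 3000 nM and 30000 nM, which means an expected step that the limit leaves unreadable from compound 3 to compound 4 that cannot be read as anything beyond the scatter.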

Compound 4, half-maximal inhibitory concentration: > 20000 nM
Compound 4: a limit, no number; the forecaster's own chance of this, stated with the estimate: 75%; middle value at least 2.0-fold (0.30 log units) away from the limit.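

Compound 1, compound 3 and compound 4 all give only limits in this assay, so neither step to compound 4 can be read. The compounds shown leave open whether 1H-imidazol-2-yl in place of 4-methylphenyl changes cytotoxicity at all.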